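This account rests on a few compounds, and the source may have more. Where it says the series, first, only, none or still open, it means among the compounds named here.

Working notes on the series. Three compounds are measured in an ADME assay on MRC5 cells (Homo sapiens) for cytotoxicity, read by fluorescence and resazurin assay, with a stated time of 3 days; on this read-out lower numbers stand for stronger inhibition and higher numbers for weaker inhibition. Compound 1 `Cc1cn(C2CCN(Cc3ccnc(Oc4ccccc4)c3)CC2)c(=O)[nH]c1=O` gives only a limit in this assay, namely > 64000 nM; that is the assay limit of > 64000 nM in this assay, at which 1 of the 3 values shown sits, and not a number. Compound 2 `Cc1cn(C2CCN(Cc3cccc(Oc4ccc(Cl)c(Cl)c4)c3)CC2)c(=O)[nH]c1=O` gives 6100 nM in this assay, and compound 3 `Cc1cn(C2CCN(Cc3cccc(Oc4cccc(Cl)c4)c3)CC2)c(=O)[nH]c1=O` gives 21000 nM. Compound 3 and compound 2 differ in one place, (chloro in place of hydrogen on an aromatic carbon), and the step in this assay is a 3.4-fold lower number from compound 3 to compound 2 (0.54 log units; beyond the scatter). Compound 4 `Cc1cn(C2CCN(Cc3ccnc(Oc4cccc(Cl)c4)c3)CC2)c(=O)[nH]c1=O` is not yet measured; it differs from compound 1 by chloro in place of hydrogen on an aromatic carbon. The difference between the core of compound 1 and the core of compound 3 is not broken down here. The change from compound 1 to compound 4 is the same kind of change as that from compound 3 to compound 2, but not the same: there the entering chloro sits ortho to a chloro group and para to a large group, here it sits meta to a large group. Given that compound 1 gives only the limit > 64000 nM in this assay, and that the measured step of this kind is a 3.4-fold lower number from compound 3 to compound 2 (0.54 log units; beyond the scatter), a step of an at least 1.2-fold lower number from compound 1 to compound 4 (0.10 log units; that floor lies within the scatter) is expected from compound 1 to compound 4. Compound 4 is estimated at 50000 nM in this assay, within 20000 nM to 150000 nM, with a fair chance that only a limit is reported.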

Compound 4, half-maximal inhibitory concentration: > 64000 nM
Compound 4: no number, only a limit (the forecaster's own chance of this, stated with the estimate: 50%); at least 1.2-fold (0.10 log units) between middle value and limit.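

Compound 1 and compound 4 both give only a limit in this assay, and no step between them can be read: the limit of > 64000 nM in this assay, at which 2 of the 4 values shown sit.

The compounds shown leave open whether 3-chlorophenoxy in place of phenoxy on the core of compound 1 changes the number in this assay at all.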